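The source may report more compounds than this note shows. Statements on the series, on what has been measured and on what is new or still open speak of the compounds shown alone.

Of the compounds shown here, three built on the same core have been measured in an ADME assay on NHDF cells (Homo sapiens) for cytotoxicity, read by MTT assay, with a stated time of 72 h; on this read-out lower numbers stand for stronger inhibition and higher numbers for weaker inhibition. Compound 1 `COc1cccc(/C=C2\CCC/C(=C\c3cccc(Cl)c3)C2=O)c1OC` gives 21400 nM in this assay. Compound 2 `COc1cccc(/C=C2\CCC/C(=C\c3ccc(O)c(O)c3)C2=O)c1OC` gives 17900 nM. Compound 3 `COc1ccc(/C=C2\CCC/C(=C\c3ccccc3Cl)C2=O)cc1OC` gives 21600 nM. Compound 3 stands at the highest of the three numbers, yet its gaps to compound 1 and to compound 2 are both within the usual scatter of repeated measurements, so the three compounds cannot be told apart on this read-out.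

The piece now follows the step from compound 3 to compound 4 `COc1ccc(/C=C2\CCC/C(=C\c3ccc(Cl)c(Cl)c3)C2=O)cc1OC`, which has not yet been measured in this assay. The change is 3,4-dichlorophenyl in place of 2-chlorophenyl on a double-bonded chain carbon bound to a double-bonded ring carbon.

Within the data shown here, only one measured step bears on such a swap of the aryl group on a double-bonded chain carbon bound to a double-bonded ring carbon: a 1.2-fold lower number from compound 1 to compound 2 (0.08 log units; within the scatter). That step exchanged one aryl group for a very different one and still moved the number by less than the scatter. With the shared core kept intact and every measured compound sitting close together, no shift beyond the scatter is expected for compound 4 in this assay.

Compound 4 is therefore estimated at 21000 nM, with a range from 10000 nM to 45000 nM, which means an expected step of a 1.0-fold lower number from compound 3 to compound 4 (0.01 log units; within the scatter).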

Compound 4, half-maximal inhibitory concentration: 10100 nM
Compound 4: middle estimate off by 2.1-fold (0.32 log units), on the high side; the range from low to high includes it.
By their numbers in this assay, from the lowest: compounds 4, 2, 1 and 3 (each within the scatter of the next, the first and the last beyond it).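

In this assay, among these compounds, the swap of 2-chlorophenyl for 3,4-dichlorophenyl on a double-bonded chain carbon bound to a double-bonded ring carbon gives a 2.1-fold lower number from compound 3 to compound 4 (0.33 log units; beyond the scatter), the first step at this position to pass beyond the scatter, though only modestly. The earlier step at this position, a 1.2-fold lower number from compound 1 to compound 2 (0.08 log units; within the scatter), stayed within the scatter, so the new result shows that not every exchange of aryl group here leaves the number in place, even though the change alters both how many chlorine atoms the aromatic ring carries and where they sit, and this single step cannot separate those two things. Nothing measured in these compounds explains why the number moved.

Still open, from the compounds shown here alone, is whether a phenyl ring with a single chlorine placed as in one of the 3,4-dichlorophenyl positions would give part of this step, and whether the same swap would act alike on the core of compound 1. Also open, going by these compounds, is how this read-out would respond at the same position to an aryl group carrying an amine or a carboxylic acid, or to a longer chain in place of the aryl group.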